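Thienopyridine carboxamides: methoxy on the thiourea phenyl

The source may hold more compounds than are shown below. What is called first, only, known or untested is meant among the compounds shown, and "the series" means these compounds.

Measured compounds:
- compound 1, `NC(=O)c1c(NC(=O)c2ccccc2F)sc2c1CCN(Cc1cccc(Cl)c1)C2`, 23300 nM
- compound 2, `NC(=O)c1c(NC(=O)c2ccccc2F)sc2c1CCN(Cc1ccc(Cl)cc1Cl)C2`, 9610 nM
- compound 3, `NC(=O)c1c(NC(=O)c2ccccc2Cl)sc2c1CCN(C(=S)Nc1ccccc1)C2`, 15600 nM

Going by the values given here, in a functional assay on MKN-74 cells (Homo sapiens) for antiproliferative activity, with a stated time of 24 h (a higher number here means a weaker inhibitor, a lower number a stronger inhibitor), compound 1 gives 23300 nM and compound 2 gives 9610 nM; the only single-point step so far is a 2.4-fold lower number from compound 1 to compound 2 (0.38 log units; beyond the scatter). Compound 3, with a thiourea on the ring nitrogen and a chlorine on the benzamide in place of fluorine, gives 15600 nM; this lies within the scatter of compound 1 and of compound 2, so no ordering among the three can be claimed.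

Compound 4, `COc1ccc(NC(=S)N2CCc3c(sc(NC(=O)c4ccccc4Cl)c3C(N)=O)C2)cc1`, differs from compound 3 only in the change (methoxy in place of hydrogen on an aromatic carbon), that is, phenyl to 4-methoxyphenyl on the thiourea. Among the compounds with values here, no measured step touches this part of the molecule: the one step in hand concerns the chlorine pattern of the benzyl group on compound 1 and compound 2, and it was modest. Nothing here supports a step beyond the scatter in either direction for compound 4 in this assay. The expectation is therefore essentially no change, a 1.0-fold lower number from compound 3 to compound 4 (0.02 log units; within the scatter), with a broad range to cover the uncertainty. Compound 4 is estimated at 15000 nM, between 5000 nM and 45000 nM.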

Compound 4, half-maximal inhibitory concentration: 19600 nM
Beside the measured number, compound 4's estimate is 1.3-fold (0.12 log units) below it; low and high end bracket the measured number.
By their numbers in this assay, from the lowest: compounds 2, 3, 4 and 1 (each within the scatter of the next, the first and the last beyond it).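

In this assay, going by these compounds alone, the first step at the thiourea side of the series reads a 1.3-fold higher number from compound 3 to compound 4 (0.10 log units; within the scatter), so compound 3 and compound 4 cannot be told apart in this read-out. At this position, on an aromatic carbon para to a large group, methoxy in place of hydrogen is therefore accepted without a measurable penalty or gain, which the earlier step on the chlorine pattern of the benzyl group could not show. The data give no explanation for this result, and no measurement here bears on one.

Only phenyl and 4-methoxyphenyl are shown on the thiourea, so it remains open whether a hydroxyl, a dimethylamino group, a carboxylic acid or a longer alkoxy chain on the same carbon would give a step beyond the scatter. Within the data shown here, the contribution of the thiourea itself also remains open, as compound 3 differs from compound 1 and compound 2 in more than one place and no single-point step links the thiourea compounds to the benzyl compounds.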